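The source may report more compounds than this note shows. Statements on the series, on what has been measured and on what is new or still open speak of the compounds shown alone.

Compound 1 `CCCC(Oc1ccc(-n2cc(OC)cn2)cc1)c1ccc(C(=O)NCCC(=O)O)cc1` is tested in an assay on cells for displacement of a labelled ligand from Glucagon receptor (Homo sapiens), in the presence of a further agent that is not named here (on this read-out higher numbers stand for weaker inhibition and lower numbers for stronger inhibition), where it gives 4400 nM, the highest of the three numbers measured. Compound 2 `CCCC(Oc1ccc(-n2cc3ccccc3n2)cc1)c1ccc(C(=O)NCCC(=O)O)cc1` gives 290 nM, and compound 3 `CCCC(Nc1cc(C)c(-n2cc(C(F)(F)F)cn2)c(C)c1)c1ccc(C(=O)NCCC(=O)O)cc1` gives 12 nM. Compound 4 `CCCC(Oc1ccc(-n2cccn2)cc1)c1ccc(C(=O)NCCC(=O)O)cc1` has not yet been measured; it differs from compound 1 by hydrogen in place of methoxy on an aromatic carbon. For the measured compounds named here, the only single-point step measured so far, a 15-fold lower number from compound 1 to compound 2 (1.18 log units; beyond the scatter), concerns a different change, a larger ring system replacing the pyrazole, so it does not directly speak to the loss of a methoxy. Compound 3 differs in several places at once. Going by the values given here, with no step that bears on this change, no shift beyond the scatter is expected. Compound 4 is therefore estimated at about 4000 nM, between 1500 nM and 12000 nM. The expected step is a 1.1-fold lower number from compound 1 to compound 4 (0.04 log units; within the scatter).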

Compound 4, inhibition constant: 4100 nM
Beside the measured number, compound 4's estimate is 1.0-fold (0.01 log units) below it; measured number inside the range.
By their numbers in this assay, from the lowest: compound 3; then compound 2; then compounds 4 and 1 (each within the scatter of the next).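

In this assay, taking the methoxy off the pyrazole gives a 1.1-fold lower number from compound 1 to compound 4 (0.03 log units; within the scatter), so at this carbon of the five-membered ring the methoxy can be lost with no shift beyond the scatter. The plain 1H-pyrazol-1-yl group also gives a second reference for the 2H-indazol-2-yl group, with a 14-fold higher number from compound 2 to compound 4 (1.15 log units; beyond the scatter) showing that the large gap seen against the methoxy compound remains without the methoxy. Nothing measured here explains either result. From the compounds shown here alone, whether an amine or a carboxylic acid on this same carbon would also leave the number unchanged remains open.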